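The source may report more compounds than this note shows. Statements on the series, on what has been measured and on what is new or still open speak of the compounds shown alone.

In a functional assay on HeLa cells (Homo sapiens) for inhibition, read by sulforhodamine B assay (a higher number here means a weaker inhibitor, a lower number a stronger inhibitor), compound 1 `CCCc1ccc(NC2=CC(=O)c3nc4n(c3C2=O)[C@H]2OC[C@@H](O)[C@H]2OC4)cc1` gives 4990 nM. Compound 2 `O=C1C(Nc2ccccc2F)=CC(=O)c2c1nc1n2[C@H]2OC[C@@H](O)[C@H]2OC1` gives 9820 nM, and compound 3 `Cc1ccc(NC2=CC(=O)c3c(nc4n3[C@H]3OC[C@@H](O)[C@H]3OC4)C2=O)cc1C` gives 4320 nM. Compound 1 lies within the scatter of both. Compound 4 `O=C1C=C(Nc2cccc(F)c2)C(=O)c2c1nc1n2[C@H]2OC[C@@H](O)[C@H]2OC1` differs from compound 1 by 3-fluorophenyl in place of 4-propylphenyl on an amine nitrogen, with 3-fluorophenyl in place of 4-propylphenyl on an amine nitrogen. Among the compounds with values here, only one measured step bears on this change: a 2.3-fold lower number from compound 2 to compound 3 (0.36 log units; beyond the scatter), a modest step that goes beyond the scatter. Within the data shown here, compound 2, the only measured compound with a fluorophenyl group, stands at 9820 nM, so a small move to a higher number in this assay is expected. The expected step is a 1.4-fold higher number from compound 1 to compound 4 (0.15 log units; within the scatter), probably within the scatter. Compound 4 is estimated at 7000 nM, with an expected range of 3000 nM to 15000 nM.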

Compound 4, half-maximal inhibitory concentration: 6440 nM
For compound 4 the middle estimate is 1.1-fold (0.04 log units) above the measured one; the range from low to high includes it.
By their numbers in this assay, from the lowest: compounds 3, 1, 4 and 2 (each within the scatter of the next, the first and the last beyond it).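

In this assay, 3-fluorophenyl in place of 4-propylphenyl on the amine nitrogen gives a 1.3-fold higher number from compound 1 to compound 4 (0.11 log units; within the scatter), so exchanging the propyl chain for a fluorine leaves the reading within the scatter. Compound 4 gives 6440 nM and compound 2, with 2-fluorophenyl, gives 9820 nM, two values within the scatter of each other. Nothing measured here bears on the reason for this result. All four compounds carry a substituted phenyl on this nitrogen. From the compounds shown here alone, whether a carboxylic acid or an amine on that phenyl, or an open alkyl chain replacing it, would read differently remains open.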